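Ester variation on a shared core: cellular tolerance notes

The source may report more compounds than this note shows. Statements on the series, on what has been measured and on what is new or still open speak of the compounds shown alone.

Measured compounds:
compound 1 `N#CCC(=O)OCCc1c(-c2ccccc2Cl)c2cc(Cl)ccc2[nH]c1=O` — in an ADME assay on HepG2 2.2.15 cells (Homo sapiens) for cytotoxicity (a higher number here means that more compound is tolerated, a lower number that less compound is tolerated), compound 1 gives 100000 nM
compound 2 `O=C(OCCc1c(-c2ccccc2Cl)c2cc(Cl)ccc2[nH]c1=O)c1ccccc1` — compound 2 gives 43000 nM
compound 3 `O=C(OCCc1c(-c2ccccc2Cl)c2cc(Cl)ccc2[nH]c1=O)c1cccs1` — compound 3 gives > 1700000 nM, a limit of this assay

Compound 1 holds the highest of the two numbers; the nearest is compound 2, with a 2.3-fold lower number from compound 1 to compound 2 (0.37 log units; beyond the scatter). Compound 3 sits at the limit (the limit of > 1700000 nM in this assay, at which 1 of the 3 values shown sits), and an at least 17-fold higher number from compound 1 to compound 3 (1.23 log units; beyond the scatter) and an at least 39-fold higher number from compound 2 to compound 3 (1.59 log units; beyond the scatter) reflect that.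

Compound 4 `COc1cccc(/C=C/C(=O)OCCc2c(-c3ccccc3Cl)c3cc(Cl)ccc3[nH]c2=O)c1` carries the change (2-(3-methoxyphenyl)ethenyl in place of cyanomethyl on a carbonyl carbon). For the measured compounds named here, the steps that bear on it, a ring-bearing acyl group in place of cyanomethyl, are a 2.3-fold lower number from compound 1 to compound 2 (0.37 log units; beyond the scatter) and an at least 17-fold higher number from compound 1 to compound 3 (1.23 log units; beyond the scatter), pointing in opposite directions, one modest and one large. No clear direction follows; a step within the scatter is the central expectation, with wide uncertainty. Compound 4 is therefore estimated at 120000 nM, in the range 30000 nM to 600000 nM. The expected step is a 1.2-fold higher number from compound 1 to compound 4 (0.08 log units; within the scatter).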

Compound 4, half-maximal cytotoxic concentration: > 1300000 nM
Compound 4: only a limit was reported; the forecaster's own chance of this, stated with the estimate: 20%; middle value at least 10-fold (1.03 log units) from the limit.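

For compound 4 the reported number is a limit: the limit of > 1300000 nM in this assay, at which 1 of the 4 values shown sits.

For the compounds shown here, on the carbonyl carbon, 2-(3-methoxyphenyl)ethenyl gives an at least 13-fold higher number from compound 1 to compound 4 (1.11 log units; beyond the scatter) and an at least 30-fold higher number from compound 2 to compound 4 (1.48 log units; beyond the scatter), so thiophen-2-yl is no longer the only acyl group standing clear of both cyanomethyl and phenyl. No step can be read between the two limits of compound 3 and compound 4.

From the compounds shown here alone, it remains open whether the ethenyl link or the methoxy group carries the step from phenyl. An acyl group bearing an amine or a carboxylic acid is also an open case.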